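Trifluoromethyl for cyclopropyl on a fused triazole core

A few compounds are considered here, and "the series" means these few. Any claim that something is new, unique, unknown or untested is made for them only; others in the source may bear on it.

Compound 1 `Cc1cc(Nc2ccc(S(F)(F)(F)(F)F)cc2)n2nc(C3CC3)nc2n1` was tested in an in vitro ADME assay on microsomes from liver (Mus musculus) for metabolic stability (on this read-out higher numbers stand for fast clearance and lower numbers for slow clearance), where compound 1 gives 12.6 mL.min-1.g-1. Compound 2 `CCc1nc2nc(C)cc(Nc3ccc(C(F)(F)F)cc3)n2n1` in this assay gives 14.4 mL.min-1.g-1; the two numbers lie within the scatter of each other, so compound 1 does not stand apart from compound 2. Compound 3 `Cc1cc(Nc2ccc(S(F)(F)(F)(F)F)cc2)n2nc(C(F)(F)F)nc2n1` has not yet been measured in this assay. It differs from compound 1 by trifluoromethyl in place of cyclopropyl on an aromatic carbon. For the measured compounds named here, no measured pair shows this change, so only a small step from compound 1 to compound 3 is expected, most likely towards slower clearance but possibly none beyond the scatter, giving a 1.4-fold lower number from compound 1 to compound 3 (0.15 log units; within the scatter). Compound 3 is therefore estimated at 9 mL.min-1.g-1, within 4 mL.min-1.g-1 to 20 mL.min-1.g-1.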

Compound 3, intrinsic clearance in microsomes: < 6 mL.min-1.g-1
Compound 3 ended at the assay's limit; the forecaster's own chance of this, stated with the estimate: 5%; middle value at least 1.5-fold (0.17 log units) from the limit.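

At this position, on an aromatic carbon between two ring nitrogen atoms, replacing cyclopropyl with trifluoromethyl gives in this assay an at least 2.1-fold lower number from compound 1 to compound 3 (0.32 log units; beyond the scatter), a step beyond the scatter. For the compounds shown here, the earlier compounds offered no pair showing this change, so this is the first sign that the position affects clearance in mouse liver microsomes. The value of compound 3 is a limit and not a number, so the step gives only a minimum size: the limit of < 6 mL.min-1.g-1 in this assay, at which 1 of the 3 values shown sits.

On these data alone, how far compound 3 lies past that limit stays open. So does whether an amine, a methoxy group or a longer chain at this position would give a similar step from compound 1.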